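Diphenylalkyl cyclic amidines: compound 1 to compound 4

The compounds below may be only part of what the source reports. "The series", "measured", "known", "first", "only" and "open" are said of these compounds alone.

Compound 1 `c1ccc(C(CCNC2=NCCCN2)c2ccccc2)cc1` carries a six-membered cyclic amidine on a chain that ends in two phenyl rings. In an assay on cell membranes with Voltage-dependent L-type calcium channel subunit alpha-1C (Rattus norvegicus) as the target (a lower number here means a stronger inhibitor, a higher number a weaker inhibitor), compound 1 returns only a limit, > 1000 nM. Compound 2 `CN1CCN=C1NCCCC(c1ccccc1)c1ccccc1` places a methylated five-membered cyclic amidine on a longer chain of the same kind; in this assay compound 2 also stops at a limit, > 1000 nM. Compound 3 `c1ccc(C(NC2=NCCN2)c2ccccc2)cc1` joins an unsubstituted five-membered cyclic amidine directly to the carbon bearing both phenyl rings, and in this assay compound 3 gives the limit > 1000 nM. Where compound 1 stands is therefore known only as the limit of > 1000 nM in this assay, at which 3 of the 3 values shown sit; no measured step between any two of the three exists, and none of the three is set apart from the others.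

Compound 4 `CN1CCN=C1NCCC(c1ccccc1)c1ccccc1` differs from compound 1 by a group of 6 heavy atoms (4 carbon, 2 nitrogen; one five-membered non-aromatic ring with 2 hetero atoms) in place of a group of 6 heavy atoms (4 carbon, 2 nitrogen; one six-membered non-aromatic ring with 2 hetero atoms), on an amine nitrogen. Within the data shown here, with every measured value sitting at a limit, no step is available to set the size or direction of this change, and the expected step is a step that the limit leaves unreadable from compound 1 to compound 4, nothing beyond the scatter in either direction. Compound 4 is expected to give about 3000 nM in this assay, within a range from 800 nM to 20000 nM, with a fair chance that only a limit is again reported.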

Compound 4, half-maximal inhibitory concentration: > 1000 nM
Compound 4: only a limit was reported; the forecaster's own chance of this, stated with the estimate: 75%; the middle value does not contradict the limit.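

In this assay compound 4 gives > 1000 nM, which is a limit. No step from compound 1 to compound 4 can be read, since both compounds stop at limits, and the whole series stands at one value: the limit of > 1000 nM in this assay, at which 4 of the 4 values shown sit.

Still open, as far as these compounds go, is where any of the four compounds actually lies, and so whether exchanging the six-membered ring for the five-membered ring changes the result at all.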